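The source may report more compounds than this note shows. Statements on the series, on what has been measured and on what is new or still open speak of the compounds shown alone.

Series notes. Among the compounds with values here, compound 3 `CCCCCCCCC#Cc1cc2cn([C@H]3C[C@H](O)[C@@H](CO)O3)c(=O)nc2o1` is the only member with a number rather than a limit in a functional assay on HEL cells (Homo sapiens) for cytotoxicity; on this read-out higher numbers stand for lower toxicity in this test and lower numbers for higher toxicity in this test: compound 3 gives 52000 nM. Compound 2 `CCCCCCC#Cc1cc2cn([C@H]3C[C@H](O)[C@@H](CO)O3)c(=O)nc2o1` sits at >= 97000 nM, which is a limit of the assay. Compound 1 `CCCCCCCCCCC#Cc1cc2cn(C)c(=O)nc2o1` sits at > 150000 nM, likewise a limit. Within the data shown here, the one measured step, an at least 1.8-fold lower number from compound 2 to compound 3 (0.27 log units; that floor lies within the scatter), concerns the chain and does not touch the change at hand. Compound 4 `CCCCCCCCC#Cc1cc2cn(C)c(=O)nc2o1` differs from compound 3 by methyl in place of 4-hydroxy-5-(hydroxymethyl)oxolan-2-yl on an aromatic nitrogen. Among the measured compounds shown here, no measured step bears on this exchange; compound 1 also carries methyl and reaches a limit (the limit of > 150000 nM in this assay, at which 1 of the 3 values shown sits). Compound 4 is therefore expected near 100000 nM (range 40000 nM to 250000 nM), an estimated step of a 1.9-fold higher number from compound 3 to compound 4 (0.28 log units; within the scatter), with a fair chance that only a limit is reported.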

Compound 4, minimum cytotoxic concentration: > 175000 nM
Compound 4 was reported as a limit; the forecaster's own chance of this, stated with the estimate: 50%; middle value at least 1.7-fold (0.24 log units) from the limit.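

With the chain held constant, methyl in place of 4-hydroxy-5-(hydroxymethyl)oxolan-2-yl on the aromatic nitrogen gives an at least 3.3-fold higher number from compound 3 to compound 4 (0.52 log units; beyond the scatter) in this assay, the first step read at this position. This step is a floor, as compound 4 gives > 175000 nM, which is a limit of the assay. The step from compound 1 to compound 4 cannot be read, as both values are limits.

As far as these compounds go, whether the exchange has the same effect on the chain of compound 2 remains open. Also open, from the compounds shown here alone, is what a 2-hydroxyethyl group on this nitrogen would give, as an intermediate between methyl and the oxolane ring.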